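From Hydroxy(phenyl)methyl to Methyl on the Shared Core

The source may report more compounds than this note shows. Statements on the series, on what has been measured and on what is new or still open speak of the compounds shown alone.

In a toxicity assay on THP-1 cells (Homo sapiens) for cytotoxicity (on this read-out lower numbers stand for an effect already at smaller amounts and higher numbers for an effect only at larger amounts of compound), compound 1 `Oc1c(-c2nnc(Cc3ccc(Cl)cc3)[nH]2)ncc2cccnc12` gives 31600 nM as a measured number. Compound 2 `Oc1c(-c2nc(C(O)c3ccccc3)n[nH]2)ncc2cccnc12` returns only a limit (> 50100 nM) and no number. Compound 3 `Cc1n[nH]c(-c2ncc3cccnc3c2O)n1` keeps the shared core and carries methyl in place of hydroxy(phenyl)methyl on an aromatic carbon. Going by the values given here, no measured pair shows this change directly. Among the compounds with values here, with compound 1 at 31600 nM as the only number available, little cytotoxicity is expected of compound 3 in this assay as well. The expected step (an at least 1.1-fold lower number from compound 2 to compound 3 (0.04 log units; that floor lies within the scatter)) stays within the scatter, in neither direction. The estimate for compound 3 is (45000 nM), with an expected range from (18000 nM) to (100000 nM).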

Compound 3, half-maximal effective concentration: > 50100 nM
Compound 3: a limit, no number; the forecaster's own chance of this, stated with the estimate: 65%; middle value at least 1.1-fold (0.04 log units) from the limit.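

No step can be read from compound 2 to compound 3 in this assay because both give only a limit and no number: the limit of > 50100 nM in this assay, at which 2 of the 3 values shown sit. The compounds shown leave open whether methyl in place of hydroxy(phenyl)methyl changes this read-out at all.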